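This account rests on a few compounds, and the source may have more. Where it says the series, first, only, none or still open, it means among the compounds named here.

Compound 3 `CC1=C(C(N)=O)C(c2ccsc2)NC(=O)N1` is the lowest of the three measured compounds, giving 1% in an assay on membranes from HEK293 cells for displacement of a labelled ligand from adenosine receptor A2b (Homo sapiens), read by scintillation counting, with a stated time of 30 min, tested at 1 uM; a higher number here means more inhibition at the concentration tested (going by the name of the read-out), a lower number less inhibition. Compound 1 `CC1=C(C(=O)OC(C)(C)C)C(c2ccsc2)NC(=O)N1` gives 47% in this assay, and compound 2 `CC1=C(C(=O)NC(C)C)C(c2cccs2)NC(=O)N1` gives 40%. Among the compounds with values here, the one measured single-point step runs from compound 1 to compound 3, where a number 46 percentage points lower from compound 1 to compound 3 (beyond the scatter), a drop far beyond the scatter. Compound 4 `CC1=C(C(=O)NC(C)C)C(c2ccsc2)NC(=O)N1` differs from compound 3 by isopropyl in place of hydrogen on an amide-type nitrogen. Within the data shown here, no measured step covers exactly this change, but compound 2 carries the same isopropylcarbamoyl group on a different thiophene attachment and sits close to compound 1. A large rise is therefore expected, with a number 37 percentage points higher from compound 3 to compound 4 (beyond the scatter). Compound 4 is estimated at 38%, with a range from 15% to 60%.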

Compound 4, a percentage reported as inhibition, at one concentration (the size of the read-out at that concentration, not a potency): 3%
Estimate against measurement, compound 4: 35 percentage points above; measured number below the stated range.
By their numbers in this assay, from the lowest: compounds 3 and 4 (each within the scatter of the next); then compounds 2 and 1 (each within the scatter of the next).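

On the thiophen-3-yl compounds, isopropyl on the amide-type nitrogen leaves this assay essentially unmoved, with a number 2 percentage points higher from compound 3 to compound 4 (within the scatter) for that change. The thiophene attachment now matters, since there is a number 37 percentage points lower from compound 2 to compound 4 (beyond the scatter) when thiophen-3-yl replaces thiophen-2-yl, so among these compounds the isopropylcarbamoyl group reaches a clearly higher number only with thiophen-2-yl. Isopropylamino in place of tert-butoxy also gives a number 44 percentage points lower from compound 1 to compound 4 (beyond the scatter) on the thiophen-3-yl core.

No evidence is available that explains these differences. Open, going by these compounds, is whether a tert-butyl amide or a methyl ester would behave like compound 1 on this core.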